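A few compounds are considered here, and "the series" means these few. Any claim that something is new, unique, unknown or untested is made for them only; others in the source may bear on it.

Measured so far:
Compound 1 `CCCCCS(=O)(=O)/C=C/c1ccc(O)c(O)c1`: 8100 nM
Compound 2 `CCCCCCCCCCCS(=O)(=O)/C=C/c1ccc(O)c(O)c1`: 11400 nM
Compound 3 `C=CCCCCCS(=O)(=O)/C=C/c1ccc(O)c(O)c1`: 7100 nM

In a functional assay, read by fluorescence and spectrophotometry, with a stated time of 1 h (on this read-out lower numbers stand for an effect already at smaller amounts and higher numbers for an effect only at larger amounts of compound), compound 3 stands within the scatter of both other compounds, as shown by a 1.1-fold lower number from compound 1 to compound 3 (0.06 log units; within the scatter) and a 1.6-fold lower number from compound 2 to compound 3 (0.21 log units; within the scatter). Compound 4 `O=S(=O)(/C=C/c1ccc(O)c(O)c1)CCCCCCCCCCCO` carries 6-hydroxyhexyl in place of vinyl on a saturated chain carbon, five bonds along the chain from a sulfonyl sulfur. The nearest evidence is a 1.6-fold lower number from compound 2 to compound 3 (0.21 log units; within the scatter), with vinyl in place of hexyl, together with a 1.4-fold higher number from compound 1 to compound 2 (0.15 log units; within the scatter). Both steps stay within the scatter, so a longer chain alone gives no reason to expect a real shift. Among the compounds with values here, no measured compound carries 6-hydroxyhexyl, which leaves that part of the change untested. The expected change is a 1.3-fold higher number from compound 3 to compound 4 (0.10 log units; within the scatter), with no step beyond the scatter in either direction. For compound 4 the estimated value is 9000 nM, with an expected range from 3500 nM to 22000 nM.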

Compound 4, half-maximal effective concentration: 22600 nM
Compound 4: middle estimate off by 2.5-fold (0.40 log units), on the low side, outside the stated range (above it).
By their numbers in this assay, from the lowest: compounds 3, 1, 2 and 4 (each within the scatter of the next, the first and the last beyond it).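

In this assay, within the data shown here, 6-hydroxyhexyl at this position gives the first steps beyond the scatter (a 3.2-fold higher number from compound 3 to compound 4 (0.50 log units; beyond the scatter); a 2.8-fold higher number from compound 1 to compound 4 (0.45 log units; beyond the scatter)), whereas all earlier chain changes stayed within it. Hydroxy in place of hydrogen on a saturated chain carbon stays within the scatter (a 2.0-fold higher number from compound 2 to compound 4 (0.30 log units; within the scatter)), so the hydroxy alone shows no real shift. Nothing available explains these differences.

Open, going by these compounds, is whether a carboxylic acid or an amine in place of that hydroxy would give a different number. Also open, on these data alone, is whether a hydroxy on a shorter chain would match compound 4.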